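A Bare Amide Gains a Branched Chain

This account rests on a few compounds, and the source may have more. Where it says the series, first, only, none or still open, it means among the compounds named here.

In an ADME assay on microsomes from liver (Mus musculus) for metabolic stability, read by mass spectrometry, with a stated time of 10 min, tested at 0.5 uM (a higher number here means that more of the compound is left, a lower number that less of the compound is left), compound 3 (`CNc1cc(Nc2cc(C)cc(C)c2)nn2c(C(N)=O)cnc12`) gives 6% as the lowest of three numbers. Compound 1 (`CNc1cc(Nc2cc(F)cc(F)c2OC)nn2c(C(=O)NCC(C)(C)CO)cnc12`) stands nearest with 24% and compound 2 (`NC(=O)c1cnc2c(NC3CC3)cc(Nc3cccc(-c4ccc(C(F)(F)F)cc4F)c3)nn12`) stands furthest with 65% and both gaps lie beyond the usual scatter. Compound 4 (`CNc1cc(Nc2cc(C)cc(C)c2)nn2c(C(=O)NCC(C)(CO)CO)cnc12`) is still unmeasured and differs from compound 3 by 2,2-bis(hydroxymethyl)propyl in place of hydrogen on an amide-type nitrogen with 2,2-bis(hydroxymethyl)propyl in place of hydrogen on an amide-type nitrogen. Going by the values given here, no measured pair shows this change alone, so any expectation is loose. Compound 1 also carries a chain on that nitrogen and gives 24% but differs elsewhere too. A moderate rise beyond the scatter is expected, an estimated step of a number 22 percentage points higher from compound 3 to compound 4 (beyond the scatter) in this measure. For compound 4 the estimated value is 28% (range 10% to 55%).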

Compound 4, percent of the compound remaining: 0%
Estimate against measurement, compound 4: 28 percentage points above; measured number below the stated range.
By their numbers in this assay, from the lowest: compounds 4 and 3 (each within the scatter of the next); then compound 1; then compound 2.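

Going by these compounds alone, putting 2,2-bis(hydroxymethyl)propyl on the amide-type nitrogen gives the first direct reading of this position: in this assay, the result is a number 6 percentage points lower from compound 3 to compound 4 (within the scatter). Within this single pair, the chain and the bare amide cannot be told apart. Nothing available here explains this outcome.

On these data alone, whether a simple methyl group, a longer chain or a chain ending in a carboxylic acid or an amine would read differently on this nitrogen remains open. So does whether the same change would behave alike on a different core.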